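This account rests on a few compounds, and the source may have more. Where it says the series, first, only, none or still open, it means among the compounds named here.

Three compounds share one core. Compound 1 `O=C1CSC(c2ccc(F)cc2)N1CCN1CCCCC1` gives 17% in an ADME assay on Vero cells (Chlorocebus sabaeus) for cytotoxicity, read by neutral red uptake, tested at 787 ug/mL; a lower number here means a stronger effect, a higher number a weaker effect of the compound at the concentration tested; compound 2 `O=C1CSC(c2c(Cl)cccc2Cl)N1CCN1CCCCC1` gives 11% in this assay; compound 3 `O=C1CSC(c2ccc([N+](=O)[O-])cc2)N1CCN1CCCCC1` gives 21% in this assay. Compound 3 thus holds the highest of the three numbers, although its gaps to compound 1 and to compound 2 both lie within the scatter. Compound 4 `Cc1ccc(C2SCC(=O)N2CCN2CCCCC2)cc1` differs from compound 3 as follows: methyl in place of nitro on an aromatic carbon. For the measured compounds named here, no measured step swaps nitro for methyl, so the one single-site step known, a number 4 percentage points higher from compound 1 to compound 3 (within the scatter), is the nearest guide; it stayed within the scatter, and no step beyond the scatter is expected in this assay here either. Compound 4 is therefore expected to give about 18%, within 8% to 28%. The expected step of a number 3 percentage points lower from compound 3 to compound 4 (within the scatter) stays within the scatter.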

Compound 4, a percentage reported as activity, at one concentration (the size of the read-out at that concentration, not a potency): 17%
For compound 4 the middle estimate is 1 percentage points above the measured one, within the range that was stated.
By their numbers in this assay, from the lowest: compounds 2, 1, 4 and 3 (each within the scatter of the next).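

In this assay, methyl at the place para to a large group gives a number 4 percentage points lower from compound 3 to compound 4 (within the scatter) and no change at the digits printed from compound 1 to compound 4 (within the scatter). A carbon-linked group at this place therefore reads within the scatter of both the nitro and the fluoro compounds, so this change from nitro to methyl separates nothing here. Nothing at hand bears on why these groups read alike. Going by these compounds, whether an amine or a carboxylic acid at this place would stay within that scatter remains open, as does the reading for a longer chain.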